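This account rests on a few compounds, and the source may have more. Where it says the series, first, only, none or still open, it means among the compounds named here.

Compound 1 `O=C1NC(=O)/C(=C\c2ccc(OCC(=O)N3N=C(c4ccccc4)CC3c3ccc(F)cc3F)cc2)S1` gives 2200 nM in an assay on cells for inhibition of histone deacetylase 4 (Homo sapiens), read by fluorescence, with a stated time of 30 min; on this read-out lower numbers stand for stronger inhibition and higher numbers for weaker inhibition. Compound 2 `O=C1NC(=O)/C(=C\c2ccc(OCC(=O)N3N=C(c4ccccc4)CC3c3ccc(Br)cc3)cc2)S1` gives 1200 nM. Among the measured compounds shown here, the step of a 1.8-fold lower number from compound 1 to compound 2 (0.26 log units; within the scatter) is the one change so far on the aryl group at the saturated ring carbon. Compound 3 `O=C1NC(=O)/C(=C\c2ccc(OCC(=O)N3N=C(c4ccc(F)cc4)CC3c3ccccc3)cc2)S1` gives 4200 nM, the highest number of the three; against compound 1 it lies within the scatter, against compound 2 beyond it.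

Compound 4 `O=C1NC(=O)/C(=C\c2ccc(OCC(=O)N3N=C(c4ccc(F)cc4)CC3c3ccc(Cl)c(Cl)c3)cc2)S1` differs from compound 3 by 3,4-dichlorophenyl in place of phenyl on a saturated ring carbon. For the measured compounds named here, the only step bearing on this place is from compound 1 to compound 2, where a halogen-pattern change on the same aryl stayed within the scatter, so no step beyond the scatter is expected in this assay. For compound 4 the estimate is 2800 nM, range 1000 nM to 7000 nM, an expected step of a 1.5-fold lower number from compound 3 to compound 4 (0.18 log units; within the scatter).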

Compound 4, half-maximal inhibitory concentration: 800 nM
Beside the measured number, compound 4's estimate is 3.5-fold (0.54 log units) above it, outside the stated range (below it).
By their numbers in this assay, from the lowest: compounds 4, 2, 1 and 3 (each within the scatter of the next, the first and the last beyond it).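

The aryl group on the saturated ring carbon can move the number beyond the scatter in this assay: 3,4-dichlorophenyl in place of phenyl gives a 5.3-fold lower number from compound 3 to compound 4 (0.72 log units; beyond the scatter). The earlier change on this aryl, a 1.8-fold lower number from compound 1 to compound 2 (0.26 log units; within the scatter), stayed within the scatter and started from an already halogenated ring. No evidence bears on the origin of the larger step. Open, on these data alone, is whether a single chlorine on the phenyl accounts for the step. Also open, as far as these compounds go, is how a phenyl carrying an amine or a carboxylic acid would read at this place.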